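A few compounds are considered here, and "the series" means these few. Any claim that something is new, unique, unknown or untested is made for them only; others in the source may bear on it.

Measured in an ADME assay on L1210/0 cells (Mus musculus) for cytotoxicity, with a stated time of 48 h; a higher number here means a weaker inhibitor, a lower number a stronger inhibitor:
Compound 1 `Nc1ncnc2c1nnn2C[C@H]1CCC[C@H]1CO`: > 200000 nM, a limit.
Compound 2 `CCOC(=O)COCn1cc(/C=C/Br)c(=O)[nH]c1=O`: > 200000 nM, a limit.
Compound 3 `O=c1[nH]c(=O)n(COCCO)cc1/C=C/Br`: > 200000 nM, a limit.

Compound 3 is known only through its limit of > 200000 nM, not through a number. The same limit holds across the series: the limit of > 200000 nM in this assay, at which 3 of the 3 values shown sit. Compound 4 `O=c1[nH]c(=O)n(COCCO)cc1[N+](=O)[O-]` keeps the (2-hydroxyethoxy)methyl group of compound 3 but carries nitro in place of 2-bromoethenyl on an aromatic carbon.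

Going by the values given here, the one measured step, a step that the two limits leave unreadable from compound 2 to compound 3, changes the chain rather than this aromatic carbon, and its size cannot be read. Among the compounds with values here, no measured step therefore bears directly on the change, and none gives a size or direction for it. In this assay, within the data shown here, the only guide is that no measured compound has given a number, so no step beyond the scatter is expected. The expected change is a number no higher from compound 3 to compound 4 (the limit leaves the size open). Compound 4 is estimated at 200000 nM, with an expected range from 70000 nM to 400000 nM.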

Compound 4, half-maximal inhibitory concentration: > 200000 nM
Compound 4 was reported as a limit; the forecaster's own chance of this, stated with the estimate: 80%; the middle value sits exactly at the limit.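

In this assay compound 3 and compound 4 are both known only as limits, so no step can be read between them: the limit of > 200000 nM in this assay, at which 4 of the 4 values shown sit.

The compounds shown leave open how nitro and 2-bromoethenyl compare on this aromatic carbon, and what number any of the compounds would give in this assay.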